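Replacing methylsulfanyl with nitro in compound 3

The source may hold more compounds than are shown below. What is called first, only, known or untested is meant among the compounds shown, and "the series" means these compounds.

Measured in a functional assay for inhibition, with Homo sapiens as the target; on this read-out lower numbers stand for tighter binding and higher numbers for weaker binding
compound 1 `Cc1ccc(C#N)c(OC(C)(C)C2OCC(C/C=C\CCC(=O)O)C(c3cccnc3)O2)c1` gives 15.9 nM
compound 2 `CC(C)(C)c1ccc(OC(C)(C)C2OCC(C/C=C\CCC(=O)O)C(c3cccnc3)O2)cc1` gives 1910 nM
compound 3 `CSc1ccccc1OC(C)(C)C1OCC(C/C=C\CCC(=O)O)C(c2cccnc2)O1` gives 89.1 nM

Among these three numbers, compound 3 at 89.1 nM is the second highest, with compound 1 lower and compound 2 higher. The next compound to be tested is compound 4 `CC(C)(Oc1ccccc1[N+](=O)[O-])C1OCC(C/C=C\CCC(=O)O)C(c2cccnc2)O1` and it differs from compound 3 by nitro in place of methylsulfanyl on an aromatic carbon in the form of nitro in place of methylsulfanyl on an aromatic carbon, ortho to a large group, so that 2-(methylsulfanyl)phenoxy becomes 2-nitrophenoxy.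

Among the measured compounds shown here, no measured step makes this exact exchange, but two bear on it indirectly. One is the modest 5.6-fold higher number from compound 1 to compound 3 (0.75 log units; beyond the scatter) and the other is the large 21-fold lower number from compound 2 to compound 3 (1.33 log units; beyond the scatter) in the same series. Compound 4 carries its new group on the same aromatic carbon as compound 3, so it is expected to fall with compound 1 and compound 3 rather than near compound 2 at 1910 nM on this evidence alone. A small step toward a lower number is therefore expected, not far beyond the scatter. The expected change is a 2.2-fold lower number from compound 3 to compound 4 (0.35 log units; beyond the scatter) in this assay by this estimate. For compound 4 the estimated value is 40 nM with an expected range from 10 nM to 150 nM in this read-out.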

Compound 4, dissociation constant: 11.2 nM
For compound 4 the middle estimate is 3.6-fold (0.55 log units) above the measured one; low and high end bracket the measured number.
By their numbers in this assay, from the lowest: compounds 4 and 1 (each within the scatter of the next); then compound 3; then compound 2.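

In this assay, the exchange of methylsulfanyl for nitro on this aromatic carbon, ortho to a large group, has a clear effect, with an 8.0-fold lower number from compound 3 to compound 4 (0.90 log units; beyond the scatter), so the identity of the group at this place matters even when both groups are small. The comparison with 2-cyano-5-methylphenyl gives a 1.4-fold lower number from compound 1 to compound 4 (0.15 log units; within the scatter), which lies within the scatter, so 2-nitrophenyl and 2-cyano-5-methylphenyl on the oxygen cannot be told apart on this read-out, although the second aryl group carries a nitrile and an added methyl. The distance from 4-(tert-butyl)phenyl is now wider, at a 170-fold lower number from compound 2 to compound 4 (2.23 log units; beyond the scatter), but that exchange alters both the group and where it stands on the ring, so it cannot be credited to the nitro group alone. Nothing shown accounts for the size of the step from methylsulfanyl to nitro. The compounds shown also leave open how an amine, a methoxy group or a chlorine atom on the same aromatic carbon would compare with nitro, and whether nitro would hold its value if a methyl group were added to the 2-nitrophenyl ring.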